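A few compounds are considered here, and "the series" means these few. Any claim that something is new, unique, unknown or untested is made for them only; others in the source may bear on it.

Measured so far in a functional assay on HeLa cells (Homo sapiens) for cytotoxicity, read by MTT assay; a higher number here means a weaker inhibitor, a lower number a stronger inhibitor:
- Compound 1 `CCCCC(CC(=O)O[C@H](CC=C(C)C)C1=CC(=O)c2c(O)ccc(O)c2C1=O)OC(C)=O`: 73500 nM
- Compound 2 `CCCC(C)(O)CC(=O)O[C@H](CC=C(C)C)C1=CC(=O)c2c(O)ccc(O)c2C1=O`: 72000 nM

Compound 2 can be compared only with compound 1, and their two values lie within the usual scatter of each other, so neither can be ranked above the other. The next compound is compound 3 `CC(C)=CC[C@@H](OC(=O)CC(C)(O)c1ccccc1)C1=CC(=O)c2c(O)ccc(O)c2C1=O`, which keeps the shared core. The structural change is phenyl in place of propyl on a saturated chain carbon bound to an oxygen on a saturated carbon and two saturated chain carbons. The group therefore goes from 1-hydroxy-1-methylbutyl to 1-hydroxy-1-phenylethyl.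

For the measured compounds named here, only one measured step bears on this change: a 1.0-fold lower number from compound 1 to compound 2 (0.01 log units; within the scatter), where 1-hydroxy-1-methylbutyl replaced 1-acetoxypentyl. Neither compound 1 nor compound 2 carries a ring in this group, so the evidence is thin. Going by a 1.0-fold lower number from compound 1 to compound 2 (0.01 log units; within the scatter), which stayed within the scatter, no shift beyond the scatter is expected in this assay. The expected change is a 1.2-fold lower number from compound 2 to compound 3 (0.08 log units; within the scatter). For compound 3 the estimated value is 60000 nM, with an expected range of 22000 nM to 120000 nM.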

Compound 3, half-maximal inhibitory concentration: 85700 nM
Compound 3: the middle estimate sits 1.4-fold (0.15 log units) below what was measured; measured number inside the range.
By their numbers in this assay, from the lowest: compounds 2, 1 and 3 (each within the scatter of the next).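

For the compounds shown here, compound 3 is the first compound here to carry a ring in this group, and it tests a much larger swap than the earlier pair did: phenyl, with 6 heavy atoms and one six-membered aromatic ring of carbon only, takes the place of propyl, with 3 heavy atoms and no ring. In this assay this change gives a 1.2-fold higher number from compound 2 to compound 3 (0.08 log units; within the scatter), so on a saturated chain carbon bound to an oxygen on a saturated carbon and two saturated chain carbons, the assay does not tell the ring from the open chain. The wider comparison agrees, with a 1.2-fold higher number from compound 1 to compound 3 (0.07 log units; within the scatter), which means that 1-acetoxypentyl, 1-hydroxy-1-methylbutyl and 1-hydroxy-1-phenylethyl cannot be ranked against one another, and no information is available to explain this result.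

On these data alone, what stays open is whether a group of another kind on this carbon, such as an amine or a carboxylic acid, would move the number beyond the scatter. The same question holds for a longer chain in place of propyl, or for a pyridine ring in place of phenyl.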